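Moving the Hydroxy Group on a Sulfonyl-Linked Phenyl

The compounds below may be only part of what the source reports. "The series", "measured", "known", "first", "only" and "open" are said of these compounds alone.

Compound 1, `O=S(=O)(Nc1ccc2oc(-c3ccccc3)nc2c1)c1cccc(Cl)c1`: > 63000 nM
Compound 2, `O=S(=O)(Nc1ccc2oc(-c3ccccc3)nc2c1)c1ccccc1Cl`: > 63000 nM
Compound 3, `O=S(=O)(Nc1ccc2oc(-c3ccccc3)nc2c1)c1cccc(O)c1`: > 63000 nM

In an assay on isolated protein for inhibition of malate dehydrogenase, mitochondrial (Sus scrofa), with stated times of 45 min and 30 min (a lower number here means a stronger inhibitor, a higher number a weaker inhibitor), compound 1 gives > 63000 nM, which is a limit of the assay and not a number. Compound 2 gives > 63000 nM in this assay, again a limit. Compound 3 gives > 63000 nM in this assay, also a limit. So compound 3 stands exactly where the other two stand: at the limit of > 63000 nM in this assay, at which 3 of the 3 values shown sit. The measured steps carry no readable size, namely a step that the two limits leave unreadable from compound 1 to compound 2, a step that the two limits leave unreadable from compound 1 to compound 3 and a step that the two limits leave unreadable from compound 2 to compound 3.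

Compound 4, `O=S(=O)(Nc1ccc2oc(-c3ccccc3)nc2c1)c1ccccc1O`, is the next compound. Its change from compound 3 is 2-hydroxyphenyl in place of 3-hydroxyphenyl on a sulfonyl sulfur. The closest measured step is the one that moved the chloro group in the same way on the same phenyl, from compound 1 to compound 2, and that step is unreadable, as are the other two. Nothing measured therefore points toward a stronger or a weaker inhibitor. The step from compound 3 to compound 4 is expected to be a number no higher from compound 3 to compound 4 (the limit leaves the size open), that is, nothing beyond the scatter. Compound 4 is estimated at 63000 nM in this assay, with a range from 20000 nM to 200000 nM, and most likely only a limit will be reported again.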

Compound 4, half-maximal inhibitory concentration: > 63000 nM
Compound 4: a limit, no number (the forecaster's own chance of this, stated with the estimate: 85%); the middle value lies on the limit itself.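

In this assay compound 4 gives > 63000 nM, again a limit of the assay and not a number. Its steps from compound 1, compound 2 and compound 3 therefore cannot be read, and all four compounds sit together: the limit of > 63000 nM in this assay, at which 4 of the 4 values shown sit. As far as these compounds go, how strongly any of the four inhibits, and whether moving the hydroxy or chloro group changes that, stays open.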